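The compounds below may be only part of what the source reports. "The series", "measured", "known", "first", "only" and "open" are said of these compounds alone.

Measured so far in a functional assay on the whole organism with Rattus norvegicus as the target; on this read-out higher numbers stand for an effect only at larger amounts of compound and lower numbers for an effect already at smaller amounts:
compound 1 `CCOCCOC(=O)C(=O)Nc1nc(-c2cc(C)no2)cs1`, 1.3 mg/kg
compound 2 `CCOCCOC(=O)C(=O)Nc1nc(-c2cc(COC)no2)cs1`, 0.7 mg/kg

Among the compounds with values here, compound 2 carries the lower of the two numbers, but the only step between them, a 1.9-fold lower number from compound 1 to compound 2 (0.27 log units; within the scatter), lies within the scatter, so no order between compound 1 and compound 2 can be claimed on these data.

Compound 3 `CCOCCOC(=O)C(=O)Nc1nc(-c2cc(C(=O)OCC)no2)cs1` is not yet measured. It differs from compound 2 as follows: ethoxycarbonyl in place of methoxymethyl on an aromatic carbon.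

Within the data shown here, no measured step exchanges methoxymethyl for ethoxycarbonyl. Among the measured compounds shown here, the single step in the set, a 1.9-fold lower number from compound 1 to compound 2 (0.27 log units; within the scatter), involves a methoxy entering on a saturated chain carbon and stays within the scatter, which gives no sign of a large movement in this assay upon altering this part of the molecule. The step of a 1.3-fold higher number from compound 2 to compound 3 (0.11 log units; within the scatter) is therefore expected to be none beyond the scatter, with wide uncertainty given the lack of a direct precedent. For compound 3 the estimate in this assay is 0.9 mg/kg, with an expected range from 0.3 mg/kg to 3 mg/kg.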

Compound 3, dose for half-maximal effect: 1.9 mg/kg
The estimate for compound 3 lay 2.1-fold (0.32 log units) below the measured number, within the range that was stated.
By their numbers in this assay, from the lowest: compounds 2, 1 and 3 (each within the scatter of the next, the first and the last beyond it).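

In this assay, this aromatic carbon next to the ring nitrogen now gives its first step beyond the scatter: ethoxycarbonyl in place of methoxymethyl gives a 2.7-fold higher number from compound 2 to compound 3 (0.43 log units; beyond the scatter), so the group here can shift the number, though only modestly. Ethoxycarbonyl in place of methyl gives a 1.5-fold higher number from compound 1 to compound 3 (0.16 log units; within the scatter), so the exchange with the smaller methyl group does not separate the two compounds, and the one readable difference at this position lies between compound 2 and compound 3. Nothing available bears on what lies behind this step.

Open, going by these compounds, is whether a carboxylic acid or an aminomethyl group on this aromatic carbon would move the number further than these three groups do. Also open, on these data alone, is whether a longer ether chain in place of methoxymethyl would hold the number near that of compound 2.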